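Sulfamoyl for methyl on the anilino ring of compound 3

This account rests on a few compounds, and the source may have more. Where it says the series, first, only, none or still open, it means among the compounds named here.

Among the measured compounds shown here, compound 3 `Cc1cccc(Nc2nccc(-c3ccncc3)n2)c1` gives 8800 nM in a functional assay for inhibition, with Homo sapiens as the target (a higher number here means a weaker inhibitor, a lower number a stronger inhibitor), the highest of the three numbers measured so far. Compound 1 `c1ccc(Nc2nccc(-c3ccncc3)n2)cc1` gives 900 nM in this assay, and compound 2 `Cc1cccc(Nc2nccc(-c3ccccn3)n2)c1` gives 700 nM. Both steps into compound 3 lie beyond the scatter: a 9.8-fold higher number from compound 1 to compound 3 (0.99 log units; beyond the scatter) and a 13-fold higher number from compound 2 to compound 3 (1.10 log units; beyond the scatter).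

Compound 4 `NS(=O)(=O)c1cccc(Nc2nccc(-c3ccncc3)n2)c1` differs from compound 3 in one place: sulfamoyl in place of methyl on an aromatic carbon.

For the measured compounds named here, no measured step involves a sulfamoyl group, so nothing bears directly on what enters. Going by the values given here, the one step at the same ring carbon is a 9.8-fold higher number from compound 1 to compound 3 (0.99 log units; beyond the scatter), which shows the methyl alone accounts for the whole rise from compound 1 to compound 3. On these data alone, removing the methyl is part of the present change, so compound 1 is the only anchor, and the contribution of the sulfamoyl itself is unknown in either direction. The step of a 13-fold higher number from compound 2 to compound 3 (1.10 log units; beyond the scatter) concerns the other ring and does not inform this change.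

The expectation for compound 4 is therefore a number lower than that of compound 3, estimated as a 5.9-fold lower number from compound 3 to compound 4 (0.77 log units; beyond the scatter), with a wide range. Compound 4 is expected to give 1500 nM, between 300 nM and 8000 nM.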

Compound 4, half-maximal inhibitory concentration: 500 nM
Beside the measured number, compound 4's estimate is 3.0-fold (0.48 log units) above it, within the range that was stated.
By their numbers in this assay, from the lowest: compounds 4, 2 and 1 (each within the scatter of the next); then compound 3.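

In this assay, the step (an 18-fold lower number from compound 3 to compound 4 (1.25 log units; beyond the scatter)) shows that the high number of compound 3 is not a general penalty for substitution at this aromatic carbon, since a sulfamoyl of 4 heavy atoms in place of the single carbon of methyl brings the number back down. The step (a 1.8-fold lower number from compound 1 to compound 4 (0.26 log units; within the scatter)) lies within the scatter, so sulfamoyl and hydrogen cannot be told apart here, and among the three substituents shown at this carbon, only methyl stands apart, with a step beyond the scatter from each of the other two. Nothing available gives a reason for the wide gap between sulfamoyl and methyl at this carbon.

Open, on these data alone, is whether a methylsulfonyl, a carboxylic acid or an amine at this carbon would group with compound 4 or with compound 3, which would show whether the result is particular to sulfamoyl or extends to other groups. Also open, as far as these compounds go, is how sulfamoyl behaves with the pyridin-2-yl of compound 2 in place of pyridin-4-yl, since methyl gives very different numbers with the two rings.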